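This account rests on a few compounds, and the source may have more. Where it says the series, first, only, none or still open, it means among the compounds named here.

Measured so far in a functional assay on the whole organism (strain Swiss albino) with Mus musculus as the target, in the maximal electroshock model, with a stated time of 0.5 h; a higher number here means that more compound is needed for the effect, a lower number that less compound is needed:
compound 1, `COc1cc2c(cc1OC)C(=O)C(CC1CCN(C(=S)Nc3cccc(C)c3)CC1)C2`: 300 mg/kg
compound 2, `COc1cc2c(cc1OC)C(=O)C(CC1CCN(C(=S)Nc3ccccc3[N+](=O)[O-])CC1)C2`: 100 mg/kg
compound 3, `COc1cc2c(cc1OC)C(=O)C(CC1CCN(C(=S)Nc3ccc([N+](=O)[O-])cc3)CC1)C2`: 30 mg/kg

All three share one core and differ only in the group on an amide-type nitrogen whose other neighbour is a thiocarbonyl carbon. Compound 3 stands lowest of the three: the step of a 3.3-fold lower number from compound 2 to compound 3 (0.52 log units; beyond the scatter) and the step of a 10-fold lower number from compound 1 to compound 3 (1.00 log units; beyond the scatter) both lie beyond the scatter, so compound 3 needs the least compound for the effect among the measured set.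

Compound 4, `CCCCNC(=S)N1CCC(CC2Cc3cc(OC)c(OC)cc3C2=O)CC1`, has not yet been measured. It differs from compound 3 in one place: butyl in place of 4-nitrophenyl on an amide-type nitrogen. Among the measured compounds shown here, none of the measured steps exchanges the aromatic ring for a chain; each keeps an aromatic ring and changes only what sits on it, as in a 3.0-fold lower number from compound 1 to compound 2 (0.48 log units; beyond the scatter). For the measured compounds named here, they show only that the group on this nitrogen matters, with the 4-nitrophenyl giving the lowest number and the 3-methylphenyl of compound 1 the highest. Taking away the 4-nitrophenyl altogether in compound 4 is therefore expected to raise the number, by a step of about a 3.3-fold higher number from compound 3 to compound 4 (0.52 log units; beyond the scatter). For compound 4 the estimate in this assay is 100 mg/kg, with a likely range from 30 mg/kg to 300 mg/kg.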

Compound 4, minimum effective dose: 100 mg/kg
Beside the measured number, compound 4's estimate shows no gap at the digits printed; the range from low to high includes it.
By their numbers in this assay, from the lowest: compound 3; then compounds 2 and 4 (each within the scatter of the next); then compound 1.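

In this assay, an aromatic ring on this amide-type nitrogen proves not to be needed for the effect: butyl, a chain with no ring, gives a 3.0-fold lower number from compound 1 to compound 4 (0.48 log units; beyond the scatter) and shows no change at the digits printed from compound 2 to compound 4 (within the scatter). The ring can still matter, depending on what it carries, since replacing 4-nitrophenyl with butyl gives a 3.3-fold higher number from compound 3 to compound 4 (0.52 log units; beyond the scatter), so among these four compounds only the 4-nitrophenyl group stands clearly ahead of the butyl chain. No measurement is available here that explains these differences.

With butyl as the only chain shown, the compounds leave open whether a shorter methyl group, a longer hexyl chain or a saturated cyclohexyl ring would lower or raise the number, so no trend with chain length can be drawn. They also leave open whether the lead of 4-nitrophenyl is specific to the nitro group or would also appear with an unsubstituted phenyl ring or with 4-chlorophenyl.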